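Three Aryl Vinyl Sulfides and One Open Exchange

This account rests on a few compounds, and the source may have more. Where it says the series, first, only, none or still open, it means among the compounds named here.

Compound 1 `Cc1ccc(S/C(=C/c2ccc(Br)cc2)C(=O)c2ccc(Cl)cc2)cc1`: 25000 nM
Compound 2 `COc1ccccc1/C=C(/SCc1ccc(Cl)c(Cl)c1)C(=O)c1ccc(Cl)cc1`: 10000 nM
Compound 3 `Cc1ccc(S/C(=C/c2ccc(Cl)cc2Cl)C(=O)c2ccc(Cl)cc2)cc1`: 10000 nM

In a functional assay on DU-145 cells (Homo sapiens) for inhibition, read by trypan blue exclusion, with a stated time of 96 h (a higher number here means a weaker inhibitor of growth, a lower number a stronger inhibitor of growth), compound 3 gives 10000 nM. That stands level with compound 2, and together they hold the lowest number of the three, while compound 1 lies clearly higher.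

The next compound to be tested is compound 4 `COc1ccccc1/C=C(/Sc1ccc(C)cc1)C(=O)c1ccc(Cl)cc1`, which has no value yet. It departs from compound 3 at one place, on a double-bonded chain carbon bound to a double-bonded chain carbon, where 2-methoxyphenyl comes in place of 2,4-dichlorophenyl: 2-methoxyphenyl in place of 2,4-dichlorophenyl on a double-bonded chain carbon bound to a double-bonded chain carbon.

Among the compounds with values here, only one measured step touches this place, and it is modest: a 2.5-fold lower number from compound 1 to compound 3 (0.40 log units; beyond the scatter). Within the data shown here, compound 2 already carries 2-methoxyphenyl there and gives 10000 nM, but it also differs from compound 4 in its sulfur substituent, so no measured step isolates the new group. The evidence is thin, and it points to a small change in this assay, with a slight drift towards a higher number at most.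

The expected move is a 1.4-fold higher number from compound 3 to compound 4 (0.15 log units; within the scatter). For compound 4 the estimated value is 14000 nM, with an expected range from 6000 nM to 35000 nM.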

Compound 4, concentration for 50% growth inhibition: 25000 nM
Beside the measured number, compound 4's estimate is 1.8-fold (0.25 log units) below it; the range from low to high includes it.
By their numbers in this assay, from the lowest: compounds 2 and 3 (each within the scatter of the next); then compounds 1 and 4 (each within the scatter of the next).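

In this assay, the exchange of 2,4-dichlorophenyl for 2-methoxyphenyl on a double-bonded chain carbon bound to a double-bonded chain carbon now has a direct measure (a 2.5-fold higher number from compound 3 to compound 4 (0.40 log units; beyond the scatter)). Set against 4-bromophenyl at the same place, 2-methoxyphenyl makes no difference (no change at the digits printed from compound 1 to compound 4 (within the scatter)), so with 4-methylphenyl on the sulfur, 2,4-dichlorophenyl alone stands apart among the three groups, as the earlier step (a 2.5-fold lower number from compound 1 to compound 3 (0.40 log units; beyond the scatter)) had only begun to suggest. The sulfur substituent also gains its first measured step, with 2-methoxyphenyl held constant: 4-methylphenyl in place of 3,4-dichlorobenzyl gives a step of the same printed size (a 2.5-fold higher number from compound 2 to compound 4 (0.40 log units; beyond the scatter)), and no measurement at hand explains either change.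

The compounds shown leave open whether 2,4-dichlorophenyl and 3,4-dichlorobenzyl, each found in a compound with a lower number, would add up if joined in one compound. They also leave open how the growth read-out would respond to an amine or a carboxylic acid on the aromatic ring at the chain carbon, or to a longer chain on the sulfur.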